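Adding Chloro to Compound 2: Expected Effect on Cell Survival

The source may hold more compounds than are shown below. What is called first, only, known or untested is meant among the compounds shown, and "the series" means these compounds.

Of the compounds shown here, two have been measured in an ADME assay on BV-2 cells (Mus musculus) for cytotoxicity, with a stated time of 24 h, tested at 50 uM; on this read-out lower numbers stand for a stronger effect and higher numbers for a weaker effect at the one concentration tested. Compound 1 `COc1ccccc1S(=O)(=O)/C=C/c1cccc(Cl)n1` gives 80.5%, while compound 2 `COc1cccc(S(=O)(=O)/C=C/c2ccccn2)c1` gives 98.9%, the higher of the two numbers, with compound 1 lying beyond the usual scatter below it. Compound 3 `COc1cccc(S(=O)(=O)/C=C/c2cccc(Cl)n2)c1` keeps the core of compound 2 and differs in one spot: chloro in place of hydrogen on an aromatic carbon. Within the data shown here, no measured pair shows this change on its own, so its effect is uncertain. A small drop in this assay is expected, a step of a number 10.9 percentage points lower from compound 2 to compound 3 (beyond the scatter) that may still sit within the scatter. Compound 3 is therefore estimated at 88%, within 70% to 100%.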

Compound 3, a percentage reported as activity, at one concentration (the size of the read-out at that concentration, not a potency): 89.3%
Compound 3: the middle estimate sits 1.3 percentage points below what was measured; measured number inside the range.
By their numbers in this assay, from the lowest: compounds 1, 3 and 2 (each within the scatter of the next, the first and the last beyond it).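

Putting chloro in place of hydrogen, next to the ring nitrogen, gives a number 9.6 percentage points lower from compound 2 to compound 3 (within the scatter) in this assay. Among these compounds, this is the first measured pair to show that change on its own, and its step cannot be told apart from the usual variation between repeats. Nothing measured here explains the step.

From the compounds shown here alone, whether an amine or a methoxy group at this same position would give a similar reading stays open. So does whether chloro would give a similar step on the core of another compound.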